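The source may hold more compounds than are shown below. What is called first, only, known or untested is meant among the compounds shown, and "the series" means these compounds.

Measured compounds:
compound 1, `CN(C)c1nccc2c1ncn2C1O[C@H](CO)[C@@H](O)[C@H]1O`, 10%
compound 2, `OC[C@H]1O[C@@H](n2cnc3c(SCc4ccccc4)nccc32)C[C@@H]1O`, 11%
compound 3, `Nc1nccc2c1ncn2[C@H]1C[C@H](O)[C@@H](CO)O1`, 89%

In a functional assay on EL4 cells (Mus musculus) for inhibition, tested at 100 uM (a lower number here means less inhibition, a higher number more inhibition at the concentration tested (going by the name of the read-out)), compound 1 gives the lowest of the three numbers, though its value and that of compound 2 lie within the usual scatter of each other, so no order between those two can be claimed. Compound 3 stands far above both. Among the compounds with values here, the only single-point step among the measured compounds is a number 78 percentage points higher from compound 2 to compound 3 (beyond the scatter), which shows that an amino group on that aromatic carbon goes with strong inhibition. Compound 1 and compound 3 differ in more than one place, so their two values can only be set side by side: compound 3 is high, compound 1 low.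

Compound 4, `CCNc1nccc2c1ncn2C1O[C@H](CO)[C@@H](O)[C@H]1O`, is the unmeasured compound; it differs from compound 1 by ethylamino in place of dimethylamino on an aromatic carbon. The measured step does not cover this exact exchange, but the contrast between compound 1 and compound 3 suggests that an ethylamino group, which keeps a hydrogen on the nitrogen as the amino of compound 3 does, may raise inhibition. An upward step of a number 35 percentage points higher from compound 1 to compound 4 (beyond the scatter) is therefore expected, with much uncertainty. Compound 4 is estimated at 45%, within 12% to 80%.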

Compound 4, a percentage reported as inhibition, at one concentration (the size of the read-out at that concentration, not a potency): 8%
Compound 4: middle estimate off by 37 percentage points, on the high side; measured number below the stated range.
By their numbers in this assay, from the lowest: compounds 4, 1 and 2 (each within the scatter of the next); then compound 3.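

In this assay, the exchange at this position gives a number 2 percentage points lower from compound 1 to compound 4 (within the scatter), so dimethylamino and ethylamino on this aromatic carbon, next to the ring nitrogen, cannot be told apart. Ethylamino has a hydrogen-bond donor and dimethylamino has none, so on the core of compound 1 this difference alone does not go with stronger inhibition. No measurement available here explains the result.

On these data alone, the large rise to an amino group was seen on the core shared by compound 2 and compound 3, so it remains open whether a plain amino group would behave the same way on the core of compound 1. Also open, as far as these compounds go, is what methylamino, or a longer chain such as propylamino, would do at this position on that core.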